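The source may hold more compounds than are shown below. What is called first, only, known or untested is meant among the compounds shown, and "the series" means these compounds.

Compound 1 `OC(c1ccc(OCc2ccc3ccccc3n2)cc1)(c1ccc(OCc2ccc3ccccc3n2)cc1)c1cccs1`: 0%
Compound 2 `CC(SCC(=O)O)(c1ccc(OCc2ccc3ccccc3n2)cc1)c1ccc(OCc2ccc3ccccc3n2)cc1`: 0%

Of the compounds shown here, two sharing a common core have been measured in a functional assay on the whole organism for inhibition, with Rattus norvegicus as the target, at a dose of 3 mg/kg; a lower number here means less inhibition, a higher number more inhibition at the dose given (going by the name of the read-out). Compound 1 gives 0% in this assay, and compound 2 gives 0%. Compound 2 therefore stands level with compound 1 at the digits recorded; the two values lie within the scatter of each other, so no order between them can be read from the numbers.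

The next compound in the series is compound 3 `O=C(O)CSC(c1ccc(OCc2ccc3ccccc3n2)cc1)(c1ccc(OCc2ccc3ccccc3n2)cc1)c1cccs1`. It is reached from compound 2 by one change: thiophen-2-yl in place of methyl on a saturated chain carbon bound to two aromatic carbons and a sulfur. Compound 3 thus carries the thiophen-2-yl group seen in compound 1 together with the sulfur-linked acid chain of compound 2.

Since compound 1 and compound 2 show the same result, the step from compound 2 to compound 3 is expected to bring no change beyond the scatter, namely a number 3 percentage points higher from compound 2 to compound 3 (within the scatter). Compound 3 is therefore estimated to give 3% in this assay, within the range 0% to 15%.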

Compound 3, a percentage reported as inhibition, in the whole organism at one dose (the size of the read-out at that dose, not a potency): 80%
Compound 3: the middle estimate sits 77 percentage points below what was measured; the measured number lies above the stated range.
By their numbers in this assay, from the lowest: compounds 1 and 2 (each within the scatter of the next); then compound 3.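

In this assay, the saturated chain carbon bound to two aromatic carbons and a sulfur proves sensitive to what it carries: thiophen-2-yl in place of methyl gives a number 80 percentage points higher from compound 2 to compound 3 (beyond the scatter). The acid chain matters as well, since (carboxymethyl)sulfanyl in place of hydroxy gives a number 80 percentage points higher from compound 1 to compound 3 (beyond the scatter), so among these compounds only compound 3, which holds both groups, shows inhibition at this dose. Nothing at hand accounts for the size of these steps.

The compounds shown leave open whether a phenyl ring or an ethyl group would serve at this carbon as thiophen-2-yl does. They also leave open whether the carboxylic acid could give way to a methyl ester or an amide, or the carboxymethyl group to a longer chain.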